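The source may hold more compounds than are shown below. What is called first, only, known or untested is meant among the compounds shown, and "the series" means these compounds.

Working notes on the series.

Compound 1 `C=CC1=C(C(=O)NCc2ccc(C)cc2)C(c2ccc(F)cc2)OC1` carries a 4-methylbenzyl amide on the shared core. In a functional assay on SW480 cells (Homo sapiens) for cytotoxicity, read by MTT assay, with a stated time of 24 h (a higher number here means a weaker inhibitor, a lower number a stronger inhibitor), compound 1 gives > 100000 nM, which is a limit of the assay and not a number. Compound 2 `C=CC1=C(C(=O)NCc2ccc(Cl)cc2)C(c2ccc(F)cc2)OC1` differs from compound 1 by chloro in place of methyl on an aromatic carbon. In this assay compound 2 gives > 100000 nM, again a limit of the assay. The step that the two limits leave unreadable from compound 1 to compound 2 therefore cannot be read, since both ends sit at the limit (the limit of > 100000 nM in this assay, at which 3 of the 3 values shown sit).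

Compound 3 `C=CC1=C(C(=O)NCc2ccc(C)cc2)C(c2ccc(OC)c(OC)c2)OC1` keeps the 4-methylbenzyl amide of compound 1 but differs from it in the other aryl part; the difference between the two cores is not broken down here. In this assay compound 3 gives > 100000 nM, a limit of the assay. Only a limit is known for compound 3, and the two other values shown are also limits.

Compound 4 `C=CC1=C(C(=O)NCc2ccc(Cl)cc2)C(c2ccc(OC)c(OC)c2)OC1` is not yet measured. It differs from compound 3 by chloro in place of methyl on an aromatic carbon, the same change that leads from compound 1 to compound 2, made on the core of compound 3 instead. Because every value shown rests at the limit of > 100000 nM in this assay, at which 3 of the 3 values shown sit, the earlier step gives no measured size to carry over. The step from compound 3 to compound 4 is expected to be a step that the limit leaves unreadable from compound 3 to compound 4, resting on the unreadable step that the two limits leave unreadable from compound 1 to compound 2 and on compound 3 giving > 100000 nM. Compound 4 is expected to give about 200000 nM in this assay, with the likely range from 80000 nM to 600000 nM, and most probably only a limit will be reported.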

Compound 4, half-maximal inhibitory concentration: > 100000 nM
Compound 4 gave a limit, no number; the forecaster's own chance of this, stated with the estimate: 85%; the middle value does not contradict the limit.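

No new step can be read, since compound 3 and compound 4 both give only a limit of the assay, and no number, in this assay: the limit of > 100000 nM in this assay, at which 4 of the 4 values shown sit.

The compounds shown leave open how large the change from 4-methylbenzyl to 4-chlorobenzyl is on either core, and which structure in this series, if any, would give a readable value in this assay.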